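From Hydrogen to Iodo: A Step Without Direct Precedent

A few compounds are considered here, and "the series" means these few. Any claim that something is new, unique, unknown or untested is made for them only; others in the source may bear on it.

In a functional assay with Cavia porcellus as the target (a higher number here means that more compound is needed for the effect, a lower number that less compound is needed), compound 3 `COC(=O)c1c(C)[nH]c(C)c1C(=O)c1ccccc1` gives 21900 nM, the second highest of the three numbers. Compound 1 `COC(=O)c1c(C)[nH]c(C)c1C(=O)c1ccccc1C(F)(F)F`, carrying trifluoromethyl, gives 4840 nM, and compound 2 `COC(=O)c1c(C)[nH]c(C)c1C(=O)c1ccccc1F`, carrying fluoro, gives 70000 nM. Compound 4 `COC(=O)c1c(C)[nH]c(C)c1C(=O)c1ccccc1I` has not yet been measured. It has iodo in place of hydrogen on an aromatic carbon, ortho to a large group: iodo in place of hydrogen on an aromatic carbon.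

Among the measured compounds shown here, two measured steps bear directly on this change. Replacing trifluoromethyl with hydrogen gives a 4.5-fold higher number from compound 1 to compound 3 (0.66 log units; beyond the scatter), while replacing fluoro with hydrogen gives a 3.2-fold lower number from compound 2 to compound 3 (0.50 log units; beyond the scatter). The two substituents therefore fall on opposite sides of compound 3, and the gap between them is wide: a 14-fold higher number from compound 1 to compound 2 (1.16 log units; beyond the scatter). No iodo comparison exists, so the direction remains uncertain. A modest step to a lower number is tentatively expected, leaning towards compound 1 at 4840 nM. The expected change is a 2.4-fold lower number from compound 3 to compound 4 (0.39 log units; beyond the scatter). Compound 4 is estimated at 9000 nM, with an expected range of 2500 nM to 30000 nM.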

Compound 4, half-maximal effective concentration: 5900 nM
For compound 4 the middle estimate is 1.5-fold (0.18 log units) above the measured one; measured number inside the range.
By their numbers in this assay, from the lowest: compounds 1 and 4 (each within the scatter of the next); then compound 3; then compound 2.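

In this assay, iodo on this aromatic carbon, ortho to a large group, moves the compound to the low side of the hydrogen of compound 3, with a 3.7-fold lower number from compound 3 to compound 4 (0.57 log units; beyond the scatter), so trifluoromethyl is no longer alone there. Iodo and trifluoromethyl cannot be told apart in this assay, with a 1.2-fold higher number from compound 1 to compound 4 (0.09 log units; within the scatter), while fluoro stands well apart from iodo, with a 12-fold lower number from compound 2 to compound 4 (1.07 log units; beyond the scatter), leaving fluoro as the only one of the three substituents with a higher number than hydrogen. Nothing measured here explains why one heavy atom, iodo, matches trifluoromethyl while fluoro goes the other way.

The compounds shown leave open whether chloro, bromo, methoxy or an amine on this carbon would fall with iodo or with fluoro. They also leave open whether this order would hold on a core other than the shared core.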